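Aryl swap on the shared core: toward compound 3

A few compounds are considered here, and "the series" means these few. Any claim that something is new, unique, unknown or untested is made for them only; others in the source may bear on it.

Measured compounds:
compound 1 `COc1ccc(-c2cn(C/C=C3\OC(=O)C(OCc4ccccc4)=C3OCc3ccccc3)nn2)cc1`: > 100000 nM
compound 2 `O=C1O/C(=C\Cn2cc(-c3ccc(Br)cc3)nn2)C(OCc2ccccc2)=C1OCc1ccccc1`: > 100000 nM

In a functional assay on HCT-116 cells (Homo sapiens) for antiproliferative activity, read by MTT assay, with a stated time of 72 h (on this read-out higher numbers stand for weaker inhibition and lower numbers for stronger inhibition), compound 1 reaches only > 100000 nM, which is a limit of the assay and not a number. Compound 2 likewise gives > 100000 nM, again a limit and not a number. The step that the two limits leave unreadable from compound 1 to compound 2 therefore cannot be sized, because of the limit of > 100000 nM in this assay, at which 2 of the 2 values shown sit. For the measured compounds named here, compound 2 thus stands at the limit, alongside compound 1; no measured value of the series lies inside the readable range, so there is no step from which a size or direction for a further change can be drawn.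

Compound 3 `O=C1O/C(=C\Cn2cc(-c3cccc(O)c3)nn2)C(OCc2ccccc2)=C1OCc1ccccc1` differs from compound 2 by 3-hydroxyphenyl in place of 4-bromophenyl on an aromatic carbon. Going by the values given here, no measured step bears on this change. Given that compound 2 sits at the limit > 100000 nM, compound 3 is expected to remain there as well, and the expected step of a number no higher from compound 2 to compound 3 (the limit leaves the size open) is none beyond the scatter. The estimate for compound 3 in this assay is 100000 nM, with a range from 30000 nM to 300000 nM, most likely reported only as a limit.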

Compound 3, half-maximal inhibitory concentration: 63600 nM
Compound 3: middle estimate off by 1.6-fold (0.20 log units), on the high side; the measured number falls inside the stated range.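

In this assay, for the compounds shown here, compound 3 is the first of the series with a number and not a limit, so this aromatic carbon of the five-membered ring, next to the ring nitrogen, now has a substituent with a readable result: 3-hydroxyphenyl, which carries 1 hydrogen-bond donor and 1 hydrogen-bond acceptor where 4-bromophenyl carries none. Replacing 4-bromophenyl gives an at least 1.5-fold lower number from compound 2 to compound 3 (0.19 log units; that floor lies within the scatter), and replacing 4-methoxyphenyl gives an at least 1.5-fold lower number from compound 1 to compound 3 (0.19 log units; that floor lies within the scatter). Each of these is a floor and not a size, and neither floor by itself separates compound 3 from the other two, because the other two compounds give only a limit: the limit of > 100000 nM in this assay, at which 2 of the 3 values shown sit.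

The change moves the substituent on the phenyl ring and alters the group at once, so the compounds shown do not tell whether the hydroxyl or its ring position goes with the readable value. Also open, going by these compounds, is how 3-aminophenyl, 3-carboxyphenyl or 4-hydroxyphenyl on the same aromatic carbon would read in this assay, and whether any such group would give a step beyond the scatter.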